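The compounds below may be only part of what the source reports. "The series", "measured", "known", "first", "only" and "open" are said of these compounds alone.

Three measured members of the series share one core and are varied at two places. Compound 1 `CCC(Sc1nc(Cl)cc(Nc2nc(-c3ccc(Cl)cc3)cs2)n1)C(=O)O` gives 3600 nM in an assay for inhibition of Polyunsaturated fatty acid 5-lipoxygenase (Homo sapiens), read by HPLC, with stated times of 15 min and 10 min; on this read-out higher numbers stand for weaker inhibition and lower numbers for stronger inhibition. Within the data shown here, compound 2 `O=C(O)C(Sc1nc(Cl)cc(Nc2nc(-c3ccc(Cl)cc3)cs2)n1)c1cccc2ccccc12` gives 400 nM in this assay; the single matched step in the set, a 9.0-fold lower number from compound 1 to compound 2 (0.95 log units; beyond the scatter), sits on the saturated chain carbon bound to a carbonyl carbon and a sulfur. Compound 3 `CCCCCCC(Sc1nc(Cl)cc(Nc2nc(-c3ccc([N+](=O)[O-])cc3)cs2)n1)C(=O)O` gives 1400 nM in this assay and stands second highest of the three numbers; the nearest is compound 1, with a higher number, the furthest compound 2, with a lower number, both gaps beyond the scatter.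

Compound 4 `CCCCCCC(Sc1nc(Cl)cc(Nc2nc(-c3ccc(OC)cc3)cs2)n1)C(=O)O` has not been measured. It differs from compound 3 in one place: methoxy in place of nitro on an aromatic carbon. Among the measured compounds shown here, no measured step bears on this position. For the measured compounds named here, compound 1 and compound 2 both carry chlorine on the outer aromatic ring, compound 3 the nitro, and the only step with a single change, from chlorine-bearing compound 1 to compound 2, alters the chain carbon instead, so the effect of a nitro-to-methoxy exchange is unknown here. With nothing to point either way, no step beyond the scatter is expected in this assay, and the expected move is a 1.1-fold higher number from compound 3 to compound 4 (0.03 log units; within the scatter). Compound 4 is estimated at 1500 nM, within 500 nM to 4500 nM.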

Compound 4, half-maximal inhibitory concentration: 800 nM
Compound 4: the middle estimate sits 1.9-fold (0.27 log units) above what was measured, and the stated range covers the measured number.
By their numbers in this assay, from the lowest: compounds 2, 4 and 3 (each within the scatter of the next, the first and the last beyond it); then compound 1.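

Among these compounds, the outer aromatic ring now has its first matched pair: in this assay the step of a 1.8-fold lower number from compound 3 to compound 4 (0.24 log units; within the scatter) is the only reading on the group para to a large group, with the rest of the molecule held constant. On this read-out, 4-nitrophenyl and 4-methoxyphenyl are not separated, even though the exchange removes the double bond of the nitro and leaves fewer heavy atoms and hydrogen-bond acceptors, so this place accepts both groups on the chain carried by compound 3 and compound 4. Nothing at hand accounts for this result or links it to any property of either group.

On these data alone, one pair of groups does not describe the position as a whole, so it remains open how an amine, a nitrile or a plain hydrogen at this place would read, and how chlorine would read on this same chain. As far as these compounds go, it is equally open whether nitro and methoxy would stay inseparable with the naphthalen-1-yl of compound 2 on the chain carbon.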